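The source may hold more compounds than are shown below. What is called first, only, known or untested is meant among the compounds shown, and "the series" means these compounds.

Within the data shown here, in a functional assay on PC-3 cells (Homo sapiens) for cytotoxicity, read by MTT assay, with a stated time of 48 h (on this read-out lower numbers stand for stronger inhibition and higher numbers for weaker inhibition), compound 2 `CC1(C)CCC[C@]2(C)[C@@H](CC[C@@](C)(O)/C=C/c3ccc(F)cc3)[C@](C)(O)CC[C@@H]12` gives 82 nM, the lower of the two numbers measured so far, while compound 1 `COc1cccc(OC)c1/C=C/[C@](C)(O)CC[C@@H]1[C@@]2(C)CCCC(C)(C)[C@@H]2CC[C@@]1(C)O` gives 4000 nM. Compound 3 `CC1(C)CCC[C@]2(C)[C@@H](CC[C@@](C)(O)/C=C/c3ccc(C(=O)O)cc3)[C@](C)(O)CC[C@@H]12` differs from compound 2 at one place: carboxy in place of fluoro on an aromatic carbon. Carboxy stands in place of fluoro on an aromatic carbon, para to a large group. Among the measured compounds shown here, only one measured step bears on this change. That step, a 49-fold lower number from compound 1 to compound 2 (1.69 log units; beyond the scatter), is large and brought in 4-fluorophenyl in place of 2,6-dimethoxyphenyl, which shows that this assay can respond strongly to a change in this part of the molecule. For the measured compounds named here, no measured compound carries carboxy, so the direction remains a judgement, and a move to a higher number, smaller than that large step, is expected. The estimated change is an 8.5-fold higher number from compound 2 to compound 3 (0.93 log units; beyond the scatter). For compound 3 the expected value is 700 nM, with an estimated range from 150 nM to 4000 nM.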

Compound 3, half-maximal inhibitory concentration: 102 nM
Compound 3: middle estimate off by 6.9-fold (0.84 log units), on the high side, outside the stated range (below it).
By their numbers in this assay, from the lowest: compounds 2 and 3 (each within the scatter of the next); then compound 1.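

In this assay, the 4-carboxyphenyl and 4-fluorophenyl compounds cannot be told apart, with a 1.2-fold higher number from compound 2 to compound 3 (0.09 log units; within the scatter). Among these compounds, the position on an aromatic carbon para to a large group therefore takes carboxy, with its three heavy atoms, its hydrogen-bond donor and its hydrogen-bond acceptor, as well as it takes a single fluorine. The large distance from the 2,6-dimethoxyphenyl compound also holds with carboxy, at a 39-fold lower number from compound 1 to compound 3 (1.59 log units; beyond the scatter), so it does not rest on fluoro alone.

Nothing available explains why these two different groups sit within the scatter of each other. On these data alone, whether an amine or a methyl ester at this same place would also stay within the scatter remains open, as does which feature of the 2,6-dimethoxyphenyl group goes with the higher number of compound 1.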